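This account rests on a few compounds, and the source may have more. Where it says the series, first, only, none or still open, it means among the compounds named here.

Series notes on a small set of thiochromenone-type compounds sharing one core. Compound 1 `S=c1cc(-c2ccccc2)oc2ccccc12` is the unsubstituted parent; in an in vitro assay on BTI-TN-5B1-4 cells for inhibition of Amine oxidase [flavin-containing] A (Homo sapiens), tested at 100 uM (a higher number here means more inhibition at the concentration tested (going by the name of the read-out), a lower number less inhibition), compound 1 gives "not active" (no number reported). Compound 2 `Cc1ccc2c(=S)cc(-c3ccccc3)oc2c1` carries a methyl on the core, and in this assay compound 2 gives "not active" (no number reported). Compound 3 `Fc1ccc2c(=S)cc(-c3ccccc3)oc2c1` carries a fluorine in place of that methyl, and in this assay compound 3 gives 40%. For the measured compounds named here, no quantified step links any pair of these three, so compound 2 stands without a single number, and compound 1 is the one further entry without a number; only compound 3 has a figure to anchor the series.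

Compound 4 `COc1ccc(-c2cc(=S)c3ccc(C)cc3o2)cc1` is the next entry to be tested. It differs from compound 2 by methoxy in place of hydrogen on an aromatic carbon. Because compound 2 gives "not active" (no number reported) the direction of this step cannot be read from the data, and the expectation is for a small step, likely none beyond the scatter. In this assay compound 4 is estimated at 15%, with a range from 0% to 40%.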

Compound 4, a percentage reported as inhibition, at one concentration (the size of the read-out at that concentration, not a potency): "not active" (no number reported)
No number was reported for compound 4, and the estimate cannot be compared.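

In this assay compound 2 gives "not active" (no number reported) and compound 4 gives "not active" (no number reported), so no step can be read between them. The compounds shown leave open what methoxy would do alongside the fluorine of compound 3, the only compound with a figure. No supporting evidence bears on this result.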